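The source may hold more compounds than are shown below. What is called first, only, known or untested is meant among the compounds shown, and "the series" means these compounds.

Measured in a toxicity assay on GES1 cells (Homo sapiens) for inhibition, read by MTT assay, with a stated time of 72 h; a higher number here means a weaker inhibitor, a lower number a stronger inhibitor:
- compound 1 `Cc1cc(N2CC[C@@H](C)[C@@H](N(C)c3ncnc4[nH]ccc34)C2)n2ncnc2n1`: 57900 nM
- compound 2 `C[C@@H]1CCN(c2cc(-c3ccccc3)nc3ncnn23)C[C@@H]1N(C)c1ncnc2[nH]ccc12`: > 100000 nM
- compound 3 `Cc1cc(N2CC[C@@H](C)[C@@H](N(C)c3ncnc4[nH]ccc34)C2)n2nc(SCCc3ccccc3)nc2n1`: 66200 nM

Compound 2 sits at the limit of > 100000 nM in this assay, at which 1 of the 3 values shown sits, so its entry is a limit and not a number. Compound 4 `CCc1cc(N2CC[C@@H](C)[C@@H](N(C)c3ncnc4[nH]ccc34)C2)n2ncnc2n1` carries ethyl in place of phenyl on an aromatic carbon. The closest measured change is an at least 1.7-fold higher number from compound 1 to compound 2 (0.23 log units; that floor lies within the scatter), for phenyl in place of methyl on an aromatic carbon. The other is a 1.1-fold higher number from compound 1 to compound 3 (0.06 log units; within the scatter), for phenethylsulfanyl in place of hydrogen. Neither goes beyond the scatter, so compound 4 is expected to stay in the range of compound 1 at 57900 nM. The expected change in this assay is an at least 1.6-fold lower number from compound 2 to compound 4 (0.22 log units; that floor lies within the scatter), toward a lower number, with nothing estimated beyond the scatter. For compound 4 the estimated value is 60000 nM, with an expected range from 30000 nM to 100000 nM.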

Compound 4, half-maximal inhibitory concentration: > 100000 nM
Compound 4 was reported as a limit; the forecaster's own chance of this, stated with the estimate: 20%; middle value at least 1.6-fold (0.22 log units) away from the limit.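

In this assay, ethyl on this aromatic carbon gives a limit and not a number, as phenyl does, so the step between those two groups cannot be read. Going from methyl to ethyl at this carbon gives an at least 1.7-fold higher number from compound 1 to compound 4 (0.23 log units; that floor lies within the scatter), so this small change shows no shift beyond the scatter, and its true size stays unknown. The limit now accounts for more of the series: the limit of > 100000 nM in this assay, at which 2 of the 4 values shown sit.

Going by these compounds, what an amine or a carboxylic acid on this aromatic carbon would give remains open. So does whether any group here would give a lower number than compound 1 at 57900 nM.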